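A few compounds are considered here, and "the series" means these few. Any claim that something is new, unique, unknown or untested is made for them only; others in the source may bear on it.

Compound 1 `Brc1ccc(-n2cc(CSc3nc4ccccc4s3)nn2)cc1` carries a 4-bromophenyl group on the shared core. Going by the values given here, in a functional assay on the whole organism (strain Albino Wistar) for inhibition, with Rattus norvegicus as the target, read by paw edema, with stated times of 1 h and 5 h, at a dose of 10 mg/kg by the oral route (on this read-out higher numbers stand for more inhibition at the one dose given (going by the name of the read-out) and lower numbers for less inhibition), compound 1 gives 59.2%, the second highest of the three numbers measured so far. Compound 3 `O[C@@H]1[C@H](O)[C@@H](O)OC(Cn2cc(CSc3nc4ccccc4s3)nn2)[C@@H]1O` gives 60.4% in this assay, a number within the scatter of that of compound 1. Among the compounds with values here, compound 2 `Cc1ccccc1-n1cc(CSc2nc3ccccc3s2)nn1` gives 43.4% in this assay, and the step of a number 15.8 percentage points lower from compound 1 to compound 2 (beyond the scatter) is the only measured step that changes a single place. Compound 4 `OCC(O)Cn1cc(CSc2nc3ccccc3s2)nn1` has not yet been measured. It differs from compound 1 in one place: 2,3-dihydroxypropyl in place of 4-bromophenyl on an aromatic nitrogen. Within the data shown here, no measured step swaps an aromatic ring for a short chain bearing hydroxyl groups, so the step from compound 1 to compound 2 bears on it only loosely, showing that a change of the group on the aromatic nitrogen can move the read-out beyond the scatter. Compound 3, whose group on the aromatic nitrogen also bears hydroxyl groups, gives a number level with compound 1, which points toward little movement. For compound 4 a step of a number 2.2 percentage points lower from compound 1 to compound 4 (within the scatter) is expected, staying within the scatter. The estimate for compound 4 in this assay is 57%, with a range from 45% to 69%.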

Compound 4, a percentage reported as inhibition, in the whole organism at one dose (the size of the read-out at that dose, not a potency): 52.8%
Estimate against measurement, compound 4: 4.2 percentage points above; measured number inside the range.
By their numbers in this assay, from the lowest: compounds 2, 4, 1 and 3 (each within the scatter of the next, the first and the last beyond it).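

In this assay, the group on the aromatic nitrogen need not contain a ring: with 2,3-dihydroxypropyl in place of 4-bromophenyl, the result is a number 6.4 percentage points lower from compound 1 to compound 4 (within the scatter) and the read-out stays close to that of the aromatic compound. With the same group in place of 2-methylphenyl, the result is a number 9.4 percentage points higher from compound 2 to compound 4 (within the scatter) and so compound 4 cannot be separated from compound 2 either, even though compound 1 and compound 2 stand apart beyond the scatter. Nothing available gives a reason for these numbers.

Still open, on these data alone, is whether an amine or a carboxylic acid at this position would keep the read-out at this level, or whether a longer chain bearing hydroxyl groups would shift it. As far as these compounds go, each number comes from a single dose, so how potency compares across these compounds also remains open.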